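Aryl swaps at the aromatic nitrogen, near the assay limit

A few compounds are considered here, and "the series" means these few. Any claim that something is new, unique, unknown or untested is made for them only; others in the source may bear on it.

Compound 1 `COc1ccc(Nc2ncc(C(F)(F)F)c(N3Cc4cccc(N(C)S(C)(=O)=O)c4C3)n2)cc1C(F)(F)F` is the reference point of this set. Going by the values given here, in a functional assay on U-87MG ATCC cells for antiproliferative activity against U-87 MG (Homo sapiens), read by spectrophotometry, with a stated time of 2 days (on this read-out higher numbers stand for weaker inhibition of growth and lower numbers for stronger inhibition of growth), compound 1 gives 29400 nM, the only outright number among the three measured members. Compound 2 `Cc1ccc(Nc2ncc(C(F)(F)F)c(N3Cc4cccc(N(C)S(C)(=O)=O)c4C3)n2)cc1C` in this assay reaches only the limit > 30000 nM. Compound 3 `COc1cc(Nc2ncc(C(F)(F)F)c(N3Cc4cccc(N(C)S(C)(=O)=O)c4C3)n2)cc(OC)c1` in this assay likewise reaches only the limit > 30000 nM. The steps of an at least 1.0-fold higher number from compound 1 to compound 2 (0.00 log units; that floor lies within the scatter) and an at least 1.0-fold higher number from compound 1 to compound 3 (0.00 log units; that floor lies within the scatter) are thus floors rather than readable sizes, both resting on (the limit of > 30000 nM in this assay, at which 2 of the 3 values shown sit). Compound 4 `Cc1cc(Cl)ccc1Nc1ncc(C(F)(F)F)c(N2Cc3cccc(N(C)S(C)(=O)=O)c3C2)n1` is the unmeasured member; it differs from compound 1 in that (4-chloro-2-methylphenyl in place of 4-methoxy-3-(trifluoromethyl)phenyl on a nitrogen on an aromatic ring). Both measured changes at that position left the number at or past the ceiling, so compound 4 is expected to sit in the same region, a 1.0-fold higher number from compound 1 to compound 4 (0.01 log units; within the scatter). Compound 4 is estimated at 30000 nM in this assay, with a range from 10000 nM to 100000 nM, and a limit-only result is quite possible.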

Compound 4, concentration for 50% growth inhibition: 28300 nM
Compound 4: the middle estimate sits 1.1-fold (0.03 log units) above what was measured; the range from low to high includes it.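

Swapping the 4-methoxy-3-(trifluoromethyl)phenyl for 4-chloro-2-methylphenyl on the nitrogen gives a 1.0-fold lower number from compound 1 to compound 4 (0.02 log units; within the scatter) in this assay. Going by these compounds alone, this is the first step at this position between two outright numbers, and it shows that a ring without methoxy or trifluoromethyl, and with fewer heavy atoms, can give a value matching that of compound 1. The steps of an at least 1.0-fold lower number from compound 3 to compound 4 (0.02 log units; that floor lies within the scatter) and an at least 1.0-fold lower number from compound 2 to compound 4 (0.02 log units; that floor lies within the scatter) are floors only, set by a limit: the limit of > 30000 nM in this assay, at which 2 of the 4 values shown sit.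

As far as these compounds go, whether any group at this position moves the number beyond the scatter remains open. A phenyl ring carrying a morpholine or a carboxylic acid would test this.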